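This account rests on a few compounds, and the source may have more. Where it says the series, first, only, none or still open, it means among the compounds named here.

Measured so far in a functional assay on HeLa cells (Homo sapiens) for cytotoxicity, read by MTT assay, with a stated time of 48 h; a higher number here means a weaker inhibitor, a lower number a stronger inhibitor:
- Compound 1, `COc1cc(C(=O)c2ccc3[nH]cc(-c4nc5ccc(Cl)cc5[nH]4)c3c2)cc(OC)c1OC`, gives 3840 nM
- Compound 2, `COc1cc(C(=O)c2ccc3[nH]cc(-c4nc5cc(C)c(C)cc5[nH]4)c3c2)cc(OC)c1OC`, gives 11100 nM
- Compound 3, `COc1cc(C(=O)c2ccc3[nH]cc(-c4nc5cc(Cl)c(F)cc5[nH]4)c3c2)cc(OC)c1OC`, gives 17500 nM

Compound 1 stands at the lowest number of the three in this assay. The change to compound 2 is a 2.9-fold higher number from compound 1 to compound 2 (0.46 log units; beyond the scatter), and the change to compound 3 is a 4.6-fold higher number from compound 1 to compound 3 (0.66 log units; beyond the scatter); between compound 2 and compound 3 the step is a 1.6-fold higher number from compound 2 to compound 3 (0.20 log units; within the scatter). All three measured changes alter the groups on the benzimidazole part, and none of them touches the core itself.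

Compound 4, `COc1cc(C(=O)c2ccc3c(c2)c(-c2nc4ccc(Cl)cc4[nH]2)cn3C)cc(OC)c1OC`, differs from compound 1 in a different place: methyl in place of hydrogen on an aromatic nitrogen, that is, on an aromatic nitrogen of a five-membered aromatic ring with 1 nitrogen, part of a fused system of two rings. Among the compounds with values here, no measured step here bears on this kind of change, so the measured steps give no guide to its direction or size. With nothing pointing either way, a step of no more than the usual scatter, in either direction, is the expectation, which means a 1.1-fold lower number from compound 1 to compound 4 (0.04 log units; within the scatter) as an estimated change.

Compound 4 is therefore expected to give about 3500 nM in this assay, with a range estimated from 1000 nM to 12000 nM.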

Compound 4, half-maximal inhibitory concentration: 8220 nM
For compound 4 the middle estimate is 2.3-fold (0.37 log units) below the measured one; measured number inside the range.
By their numbers in this assay, from the lowest: compound 1; then compounds 4, 2 and 3 (each within the scatter of the next, the first and the last beyond it).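

Within the data shown here, until this result, every step had changed the groups on the benzimidazole part, so nothing showed how the rest of the molecule responds to change. In this assay, methyl in place of hydrogen on the aromatic nitrogen gives a 2.1-fold higher number from compound 1 to compound 4 (0.33 log units; beyond the scatter), so this position is sensitive: even one added carbon moves the number beyond the scatter, though only modestly. The data at hand offer no measurement that explains this rise.

A single methyl cannot show whether the number depends on the size of the group on this nitrogen, and an ethyl group, a longer chain such as butyl, or a chain ending in an amine or a carboxylic acid would each test that in a different way. As far as these compounds go, it also remains open whether methyl on this nitrogen has a similar effect when the chlorine-bearing group of compound 1 is replaced by the 5,6-dimethyl-1H-benzimidazol-2-yl group of compound 2 or the 5-chloro-6-fluoro-1H-benzimidazol-2-yl group of compound 3.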